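The source may report more compounds than this note shows. Statements on the series, on what has been measured and on what is new or still open speak of the compounds shown alone.

Series notes. Compound 1 `O=C(Nc1nc(-c2ccccc2)cs1)c1ccc([N+](=O)[O-])o1` is the parent without any substituent on its aryl group; in an ADME assay on Vero cells (Chlorocebus sabaeus) for cytotoxicity, read by MTT assay, with a stated time of 72 h (a lower number here means a stronger inhibitor, a higher number a weaker inhibitor), compound 1 gives 41700 nM. Compound 2 `COc1cccc(-c2csc(NC(=O)c3ccc([N+](=O)[O-])o3)n2)c1` carries a 3-methoxyphenyl instead, and compound 2 gives 58700 nM. Compound 3 `COc1ccccc1-c1csc(NC(=O)c2ccc([N+](=O)[O-])o2)n1` carries a 2-methoxyphenyl, and compound 3 gives 42000 nM. Compound 3 stands among the three numbers with nothing that sets it apart: the step of a 1.0-fold higher number from compound 1 to compound 3 (0.00 log units; within the scatter) and the step of a 1.4-fold lower number from compound 2 to compound 3 (0.15 log units; within the scatter) both lie within the scatter, as does the step of a 1.4-fold higher number from compound 1 to compound 2 (0.15 log units; within the scatter).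

Compound 4 `O=C(Nc1nc(-c2cccc(F)c2)cs1)c1ccc([N+](=O)[O-])o1` has not been measured. It differs from compound 3 by 3-fluorophenyl in place of 2-methoxyphenyl on an aromatic carbon. The measured steps that bear on this change are the exchanges on the aryl group already seen: hydrogen to methoxy on an aromatic carbon in a 1.0-fold higher number from compound 1 to compound 3 (0.00 log units; within the scatter) and in a 1.4-fold higher number from compound 1 to compound 2 (0.15 log units; within the scatter), and the shift from 3-methoxyphenyl to 2-methoxyphenyl in a 1.4-fold lower number from compound 2 to compound 3 (0.15 log units; within the scatter); none of them moved the number beyond the scatter. For the measured compounds named here, no measured step involves a fluorine, so the expectation rests on these aryl variants alone. The expected step of a 1.1-fold higher number from compound 3 to compound 4 (0.03 log units; within the scatter) is therefore none beyond the scatter. Compound 4 is estimated at 45000 nM, with a range from 25000 nM to 85000 nM.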

Compound 4, half-maximal inhibitory concentration: 51600 nM
Estimate against measurement, compound 4: 1.1-fold (0.06 log units) below, within the range that was stated.
By their numbers in this assay, from the lowest: compounds 1, 3, 4 and 2 (each within the scatter of the next).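

In this assay, for the compounds shown here, fluorine appears on the aryl group for the first time, and neither fluoro in place of hydrogen, a 1.2-fold higher number from compound 1 to compound 4 (0.09 log units; within the scatter), nor fluoro in place of methoxy, a 1.1-fold lower number from compound 2 to compound 4 (0.06 log units; within the scatter), moves the number beyond the scatter. Replacing the substituted aryl group as a whole, with 3-fluorophenyl in place of 2-methoxyphenyl on the aromatic carbon next to the ring nitrogen, gives a 1.2-fold higher number from compound 3 to compound 4 (0.09 log units; within the scatter), so this position also shows no step beyond the scatter when the hydrogen-bond acceptor count of the group falls from 1 to 0. No available measurement accounts for this flat response across the four compounds.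

On these data alone, all four compounds carry an uncharged phenyl group at this position, so the response to an aryl group bearing an amine or a carboxylic acid, or to a longer alkyl chain in place of the phenyl group, remains open. As far as these compounds go, whether these exchanges would stay equally flat in a read-out other than this assay also remains open.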